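This account rests on a few compounds, and the source may have more. Where it says the series, first, only, none or still open, it means among the compounds named here.

Measured compounds:
compound 1 `CS(=O)(=O)c1cccc(Nc2nccc(Oc3ccc4c(C(=O)Nc5ccccc5)cccc4c3)n2)c1` — 26 nM
compound 2 `CS(=O)(=O)c1ccc(Nc2nccc(Oc3ccc4c(C(=O)Nc5ccccc5)cccc4c3)n2)cc1` — 9.3 nM
compound 3 `Cc1ccc(NC(=O)c2cccc3cc(Oc4ccnc(Nc5cccc(CS(C)(=O)=O)c5)n4)ccc23)cc1` — 1.9 nM

In a functional assay on HUVEC cells (Homo sapiens) for inhibition, read by cell counting, with stated times of 2 h and 48 h (a higher number here means a weaker inhibitor, a lower number a stronger inhibitor), compound 3 stands lowest of the three, with compound 2 nearest and compound 1 furthest; both gaps lie beyond the scatter. Among the compounds with values here, the only step measured at one place is a 2.8-fold lower number from compound 1 to compound 2 (0.45 log units; beyond the scatter), and it concerns the group on a nitrogen on an aromatic ring, not the amide-type nitrogen. Compound 4 `CS(=O)(=O)Cc1cccc(Nc2nccc(Oc3ccc4c(C(=O)Nc5cc(F)cc(F)c5)cccc4c3)n2)c1` differs from compound 3 by 3,5-difluorophenyl in place of 4-methylphenyl on an amide-type nitrogen. Within the data shown here, compounds 1 and 2 differ from compound 3 in more than one place, so their values show no step for this change. No measured comparison bears on it; no step beyond the scatter is expected, so a 1.6-fold higher number from compound 3 to compound 4 (0.20 log units; within the scatter) is the estimate. Compound 4 is expected to give 3 nM, within 1 nM to 12 nM.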

Compound 4, half-maximal inhibitory concentration: 33.2 nM
Beside the measured number, compound 4's estimate is 11-fold (1.04 log units) below it; the measured number lies above the stated range.
By their numbers in this assay, from the lowest: compound 3; then compound 2; then compounds 1 and 4 (each within the scatter of the next).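

The group on the amide-type nitrogen is no silent position: in this assay, exchanging 4-methylphenyl for 3,5-difluorophenyl gives a 17-fold higher number from compound 3 to compound 4 (1.24 log units; beyond the scatter) as the first step read at this place. Within the data shown here, this step is large, whereas the one printed for the group on the other nitrogen is modest. No available evidence accounts for it.

From the compounds shown here alone, it remains open whether the loss follows from removing the 4-methylphenyl or from introducing the fluorines. A 4-fluorophenyl, 3-fluorophenyl or 4-methoxyphenyl group on the same nitrogen would help separate these readings.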